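Swapping Propoxycarbonyl for Benzyloxycarbonyl in a Weak Antiproliferative Series

The source may hold more compounds than are shown below. What is called first, only, known or untested is meant among the compounds shown, and "the series" means these compounds.

For the measured compounds named here, in a functional assay on MDA-MB-231 cells (Homo sapiens) for antiproliferative activity, read by MTT assay, with a stated time of 48 h (on this read-out higher numbers stand for weaker inhibition of growth and lower numbers for stronger inhibition of growth), compound 2 (`CCCOC(=O)N1N=C(c2cccc(OC)c2)CC1c1cc(OC)c(OC)c(OC)c1`) gives 12500 nM, the only actual number available. Compound 1 (`COc1cc(C2CC(c3ccccc3)=NN2C(=O)OCc2ccccc2)cc(OC)c1OC`), which carries benzyloxycarbonyl, gives > 10000 nM, and this is a limit of the assay and not a number. Compound 3 (`COc1cccc(C2=NN(C(=O)OCc3ccccc3)C(c3cc(OC)c(OC)c(OC)c3)C2)c1`) is compound 2 with one change, phenyl in place of ethyl on a saturated chain carbon bound to an oxygen next to a carbonyl group, so that propoxycarbonyl becomes benzyloxycarbonyl. Going by the values given here, no measured pair isolates this change, so its effect in this assay can only be judged loosely. No shift beyond the usual scatter is expected, and the estimated step is a 1.3-fold lower number from compound 2 to compound 3 (0.10 log units; within the scatter). Activity should remain weak, and a result reported only as a limit would not be surprising. Compound 3 is expected at 10000 nM, with an estimated range of 3000 nM to 30000 nM.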

Compound 3, concentration for 50% growth inhibition: > 10000 nM
Compound 3 ended at the assay's limit (the forecaster's own chance of this, stated with the estimate: 35%); the middle value lies on the limit itself.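

The steps from compound 2 to compound 3 and from compound 1 to compound 3 cannot be read in this assay, because compound 1 and compound 3 stand at a limit and not at a number: the limit of > 10000 nM in this assay, at which 2 of the 3 values shown sit. The compounds shown leave open whether either benzyloxycarbonyl or methoxy changes growth inhibition at all.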